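A few compounds are considered here, and "the series" means these few. Any claim that something is new, unique, unknown or untested is made for them only; others in the source may bear on it.

Of the compounds shown here, three have so far been measured in a functional assay on KG-1 cells (Homo sapiens) for cytotoxicity, read by luminescence and CellTiter-Glo, with a stated time of 3 days; on this read-out higher numbers stand for weaker inhibition and lower numbers for stronger inhibition. Compound 1, `O=C(Nc1ccc(OC(F)(F)F)c(Cl)c1)c1ccc(C(F)(F)F)cc1O`, gives 640 nM in this assay. Compound 2, `N#Cc1ccc(NC(=O)c2cc(-c3ccncc3)ccc2O)cc1`, gives 7990 nM, and compound 3, `Cc1cc(C#N)ccc1NC(=O)c1ccc2cccnc2c1O`, gives 3240 nM. Among these three numbers compound 2 stands highest: compound 3 lies nearest, with a lower number beyond the scatter, and compound 1 lies furthest, with a lower number also beyond the scatter.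

Compound 4, `COc1ccc(O)c(C(=O)Nc2ccc(C#N)cc2)c1`, has not yet been measured. It differs from compound 2 in one place: methoxy in place of pyridin-4-yl on an aromatic carbon. The group that enters sits on an aromatic carbon of a six-membered aromatic ring of carbon only, meta to a large group and para to a hydroxy group.

Among the compounds with values here, no measured pair shows this change, so its size cannot be read from the numbers so far. The step expected is a 1.1-fold higher number from compound 2 to compound 4 (0.05 log units; within the scatter), a move no larger than the scatter and in no firm direction. The estimate for compound 4 in this assay is 9000 nM, in the range from 3000 nM to 27000 nM.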

Compound 4, half-maximal inhibitory concentration: > 10000 nM
Compound 4 was reported as a limit (the forecaster's own chance of this, stated with the estimate: 10%); middle value at least 1.1-fold (0.04 log units) from the limit.
By their numbers in this assay, from the lowest: compound 1; then compound 3; then compound 2. At a limit, above all of these: compound 4.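

Methoxy in place of pyridin-4-yl on this aromatic carbon, para to a hydroxy group, gives the first reading of any change at this position in this assay: an at least 1.2-fold higher number from compound 2 to compound 4 (0.09 log units; that floor lies within the scatter). The change brings no sign of stronger inhibition, though the floor of the step alone does not show a real loss of activity. The reading for compound 4 is a limit and not a number, so the full size of the step cannot be told: the limit of > 10000 nM in this assay, at which 1 of the 4 values shown sits.

Going by these compounds, how far the true number of compound 4 lies beyond that limit stays open, and with it whether the step exceeds the scatter. Also open, on these data alone, is what an amine, a carboxylic acid or a longer chain such as propoxy would give on this same aromatic carbon.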